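Moving the sulfamoyl group on the pendant phenyl

The compounds below may be only part of what the source reports. "The series", "measured", "known", "first", "only" and "open" are said of these compounds alone.

Compound 1 `O=C(O)Cc1sc(C(c2ccc(F)cc2)c2ccc(F)cc2)nc1-c1ccc(Cl)cc1` sets the low end of the series: in an in vitro assay on HEK385-7 cells for displacement of a labelled ligand from prostaglandin D2 receptor 2 (Homo sapiens) (on this read-out higher numbers stand for weaker inhibition and lower numbers for stronger inhibition), compound 1 gives 9.7 nM. Compound 2 `O=C(O)Cc1sc(C(c2ccc(F)cc2)c2ccc(F)cc2)nc1-c1cc(F)cc(F)c1` gives 35 nM, a step of a 3.6-fold higher number from compound 1 to compound 2 (0.56 log units; beyond the scatter). Compound 3 `NS(=O)(=O)c1ccc(-c2nc(C(c3ccc(F)cc3)c3ccc(F)cc3)sc2CC(=O)O)cc1` gives 1500 nM, the highest number of the three; the steps leading to it are a 150-fold higher number from compound 1 to compound 3 (2.19 log units; beyond the scatter) and a 43-fold higher number from compound 2 to compound 3 (1.63 log units; beyond the scatter). Compound 4 `NS(=O)(=O)c1cccc(-c2nc(C(c3ccc(F)cc3)c3ccc(F)cc3)sc2CC(=O)O)c1` keeps every atom of compound 3 and only relocates the sulfamoyl group: 3-sulfamoylphenyl in place of 4-sulfamoylphenyl on an aromatic carbon. Among the measured compounds shown here, no measured step moves a substituent around the phenyl while keeping the substituent itself, so nothing bears on this change directly; the only change of substitution pattern, a 3.6-fold higher number from compound 1 to compound 2 (0.56 log units; beyond the scatter), also swapped the groups and was modest. Both large steps into compound 3 arise with the sulfamoylphenyl present, and that group remains present in compound 4, so a number near that of compound 3 is expected. For compound 4 a step of about a 1.3-fold lower number from compound 3 to compound 4 (0.10 log units; within the scatter) is therefore expected, within the scatter, with an estimate of 1200 nM, ranging from 300 nM to 5000 nM.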

Compound 4, half-maximal inhibitory concentration: 140 nM
The estimate for compound 4 lay 8.6-fold (0.93 log units) above the measured number; measured number outside the range, below it.
By their numbers in this assay, from the lowest: compound 1; then compound 2; then compound 4; then compound 3.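

In this assay the placement of the sulfamoyl group on the pendant phenyl matters in its own right, with no atom gained or lost: 3-sulfamoylphenyl in place of 4-sulfamoylphenyl gives an 11-fold lower number from compound 3 to compound 4 (1.03 log units; beyond the scatter), so the large rise seen with 4-sulfamoylphenyl cannot be assigned to the sulfamoyl group alone. Relocation does not close the gap to the halogen-bearing rings, with a 4.0-fold higher number from compound 2 to compound 4 (0.60 log units; beyond the scatter) and a 14-fold higher number from compound 1 to compound 4 (1.16 log units; beyond the scatter). Nothing at hand explains the difference between the two placements.

From the compounds shown here alone, it remains open whether this relocation would have a similar effect with a methylsulfonyl group or a carboxylic acid in place of the sulfamoyl group. Also open, going by these compounds, is how a methyl group on the sulfamoyl nitrogen would shift the number for compound 4.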